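A Methyl Added to the Ring of Compound 3

The source may report more compounds than this note shows. Statements on the series, on what has been measured and on what is new or still open speak of the compounds shown alone.

Compounds measured in a functional assay on NCI-H661 cells (Homo sapiens) for cytotoxicity, read by WST assay, with a stated time of 72 h; on this read-out lower numbers stand for stronger inhibition and higher numbers for weaker inhibition:
compound 1 `COc1cc2c(Nc3nc4ccc(C(=O)Nc5c(C)cccc5Cl)cc4s3)ncnc2cc1OCCCN1CCCCC1C` gives 5300 nM
compound 2 `CCN(CC)CCCOc1cc2ncnc(Nc3nc4ccc(C(=O)Nc5c(C)cccc5Cl)cc4s3)c2cc1OC` gives 11200 nM
compound 3 `COc1cc2c(Nc3nc4ccc(C(=O)Nc5c(C)cccc5Cl)cc4s3)ncnc2cc1OCCCN1CCCCC1` gives 13800 nM

Among these three, compound 3 carries the highest number. Compound 2 sits within the scatter of it, as a 1.2-fold higher number from compound 2 to compound 3 (0.09 log units; within the scatter) shows, so no order between compound 2 and compound 3 can be read; compound 1 lies clearly lower, as a 2.6-fold higher number from compound 1 to compound 3 (0.42 log units; beyond the scatter) shows.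

Compound 4 `COc1cc2c(Nc3nc4ccc(C(=O)Nc5c(C)cccc5Cl)cc4s3)ncnc2cc1OCCCN1CCC(C)CC1` differs from compound 3 by methyl in place of hydrogen on a saturated ring carbon. For the measured compounds named here, the one measured step that bears on this change is a 2.6-fold higher number from compound 1 to compound 3 (0.42 log units; beyond the scatter), in which a methyl on a saturated ring carbon was removed and the number rose; read backwards, adding such a methyl lowered the number. The methyl in compound 4, though, sits three ring bonds from the ring nitrogen, a different place from the methyl of compound 1, so that step is only a loose guide. The steps of a 2.1-fold higher number from compound 1 to compound 2 (0.32 log units; beyond the scatter) and a 1.2-fold higher number from compound 2 to compound 3 (0.09 log units; within the scatter) exchange the whole amine and add little here.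

For compound 4 a modest lowering, or no change beyond the scatter, is expected, namely a 1.5-fold lower number from compound 3 to compound 4 (0.19 log units; within the scatter). The estimated value for compound 4 is 9000 nM, with a range from 4000 nM to 25000 nM.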

Compound 4, half-maximal inhibitory concentration: 7900 nM
The estimate for compound 4 lay 1.1-fold (0.06 log units) above the measured number; measured number inside the range.
By their numbers in this assay, from the lowest: compounds 1, 4, 2 and 3 (each within the scatter of the next, the first and the last beyond it).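

In this assay, a methyl on the saturated ring carbon three ring bonds from the ring nitrogen gives a step that cannot be told from no change, a 1.7-fold lower number from compound 3 to compound 4 (0.24 log units; within the scatter). Compound 4 also cannot be separated from the compound with its methyl elsewhere on the ring, a 1.5-fold higher number from compound 1 to compound 4 (0.17 log units; within the scatter), or from the open-chain amine, a 1.4-fold lower number from compound 2 to compound 4 (0.15 log units; within the scatter), so the new compound sets no order among these neighbours. No measurement shown here offers an explanation for these numbers.

Going by these compounds, it remains open whether a larger group on the same ring carbon, such as ethyl or phenyl, would move the number beyond the scatter. Also unsettled is what a hydroxyl there, or morpholin-4-yl in place of the whole piperidin-1-yl group, would give.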